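The compounds below may be only part of what the source reports. "The series", "measured", "known", "first", "only" and "open" are said of these compounds alone.

Measured so far:
compound 1 `O=C1c2c[n+]([O-])c3ccccc3c2C(=O)c2c1c1ccccc1n2CCCCn1ccnc1` — in a functional assay on MCF7 cells (Homo sapiens) for cytotoxicity, read by MTT assay, with a stated time of 72 h (on this read-out higher numbers stand for weaker inhibition and lower numbers for stronger inhibition), compound 1 gives 130 nM
compound 2 `CC1(C)OC[C@H](Cn2cc(Cn3c4c(c5ccccc53)C(=O)c3c[n+]([O-])c5ccccc5c3C4=O)nn2)O1` — in this assay compound 2 gives 530 nM

Of the two numbers, compound 1 gives the lower one; compound 2 sits well above it, a gap beyond the scatter. Going by the values given here, the two measured compounds do not differ in one place only, so no single structural step has yet been charted, and the size of any one change remains unknown.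

Compound 3 `CN1CCN(CCCn2c3c(c4ccccc42)C(=O)c2c[n+]([O-])c4ccccc4c2C3=O)CC1` has not been measured. Against compound 1 the change is 4-methylpiperazin-1-yl in place of (1H-imidazol-1-yl)methyl on a saturated chain carbon, three bonds along the chain from an aromatic nitrogen. Among the compounds with values here, no measured pair shows a change of this kind, so the expectation rests on compound 1 alone and carries a wide range. In this assay compound 3 is expected to show a step of a 1.2-fold higher number from compound 1 to compound 3 (0.06 log units; within the scatter) that stays within the scatter, with no clear direction. The estimate for compound 3 is 150 nM, expected to fall between 50 nM and 450 nM.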

Compound 3, half-maximal inhibitory concentration: 220 nM
Compound 3: the middle estimate sits 1.5-fold (0.17 log units) below what was measured, within the range that was stated.
By their numbers in this assay, from the lowest: compounds 1 and 3 (each within the scatter of the next); then compound 2.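

In this assay this position takes 4-methylpiperazin-1-yl in place of (1H-imidazol-1-yl)methyl with a step that stays within the scatter (a 1.7-fold higher number from compound 1 to compound 3 (0.23 log units; within the scatter)), the first single-place step charted in the series. A five-membered aromatic ring and a six-membered non-aromatic ring thus give values that cannot be told apart here, although the same difference also reads as 4-(1H-imidazol-1-yl)butyl to 3-(4-methylpiperazin-1-yl)propyl, so chain and ring change together in this one step. No supporting data bear on this result.

Still open, from the compounds shown here alone, is how much the chain itself contributes, which a 4-(4-methylpiperazin-1-yl)butyl group or a 3-(1H-imidazol-1-yl)propyl group at this position would separate from the ring. Also open, going by these compounds, is whether a chain ending in a carboxylic acid or a primary amine stays in the same range.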